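The compounds below may be only part of what the source reports. "The series", "measured", "known", "first", "only" and "open" are said of these compounds alone.

Measured in an ADME assay on HEK-293T cells (Homo sapiens) for cytotoxicity, read by CCK-8 assay, with a stated time of 24 h; on this read-out higher numbers stand for lower toxicity in this test and lower numbers for higher toxicity in this test:

Compound 1, `Cc1ccc(NC(=O)c2ccc(CN3CCN(C)CC3)cc2)cc1-n1cc(-c2cnc3cccnn23)cn1`, gives 23800 nM.
Compound 2, `Cc1ccc(NC(=O)c2ccc(C(F)(F)F)cc2)cc1-n1cc(-c2cnc3cccnn23)cn1`, gives only a limit, > 80000 nM.
Compound 3, `Cc1ccc(NC(=O)c2cccc(Cl)c2)cc1-n1cc(-c2cnc3cccnn23)cn1`, gives only a limit, > 80000 nM.

Compound 2 therefore has no exact number in this assay; its result is a limit, and the limit of > 80000 nM in this assay, at which 2 of the 3 values shown sit, shows that compound 3 sits at the same limit. For the measured compounds named here, the step of an at least 3.3-fold higher number from compound 1 to compound 2 (0.52 log units; beyond the scatter), which exchanges a trifluoromethyl for a (4-methylpiperazin-1-yl)methyl on an aromatic carbon, is the only readable step here, and it moves toward lower toxicity. The step that the two limits leave unreadable from compound 2 to compound 3 cannot be sized because both ends are limits.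

Compound 4, `Cc1ccc(NC(=O)c2ccc(C(F)(F)F)cc2)cc1-n1cc(-c2cnc3ccnn3c2)cn1`, keeps the amide part of compound 2 and changes the bicyclic group on the other side: a group of 9 heavy atoms (6 carbon, 3 nitrogen; one five-membered aromatic ring with 2 hetero atoms, one six-membered aromatic ring with 2 hetero atoms) in place of a group of 9 heavy atoms (6 carbon, 3 nitrogen; one five-membered aromatic ring with 2 hetero atoms, one six-membered aromatic ring with 2 hetero atoms), on an aromatic carbon. The change sits on an aromatic carbon. Neither measured step touches this part of the molecule, so nothing shown speaks directly to its effect. With compound 2 at the limit, compound 4 is expected to stay near it, so the step of a number no higher from compound 2 to compound 4 (the limit leaves the size open) is expected to be small. The estimate for compound 4 is 80000 nM, within 30000 nM to 200000 nM.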

Compound 4, half-maximal cytotoxic concentration: 43200 nM
Beside the measured number, compound 4's estimate is 1.9-fold (0.27 log units) above it; the range from low to high includes it.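

In this assay, for the compounds shown here, compound 4 gives 43200 nM, which is the first exact number for a compound carrying the trifluoromethyl amide part, and it comes from a bicyclic group with the same atoms and the same counted features, only joined differently. The step on this aromatic carbon is an at least 1.8-fold lower number from compound 2 to compound 4 (0.26 log units; that floor lies within the scatter), so rejoining these atoms may matter for this read-out, but the printed floor alone does not establish a real change. Compound 2 remains a limit and not a number, so the true size of the step stays unknown and could exceed its floor: the limit of > 80000 nM in this assay, at which 2 of the 4 values shown sit.

The compounds shown leave open whether the step seen with the (4-methylpiperazin-1-yl)methyl group from compound 1 to compound 2 would repeat with the bicyclic group of compound 4, since no such pair stands here. They also leave open how a morpholine ring or a carboxylic acid on the amide's aromatic ring, or a single pyridine ring in place of either bicyclic group, would read in this assay.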